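This account rests on a few compounds, and the source may have more. Where it says the series, first, only, none or still open, it means among the compounds named here.

Compound 1, `O=C(Nc1cccc(Cl)c1)Nc1cccc(CNc2nccnc2Cl)c1`: 5330 nM in a functional assay on MGC-803 cells (Homo sapiens) for antiproliferative activity, read by MTT assay, with a stated time of 48 h; on this read-out higher numbers stand for weaker inhibition and lower numbers for stronger inhibition. Compound 2, `O=C(Nc1cccc(CNc2nccnc2Cl)c1)Nc1cccc2ccccc12`: 32700 nM in this assay.

Of these two, compound 1 has the lower number, and compound 2 stands beyond the usual scatter above it. Compound 3, `O=C(Nc1cccc(CNc2nccnc2Cl)c1)Nc1ccccc1Cl`, has not yet been tested. It differs from compound 1 only in the placement of one chlorine: 2-chlorophenyl in place of 3-chlorophenyl on an amide-type nitrogen. Such a rearrangement, with no change in the atoms present, is expected to shift the result only modestly, most likely toward a somewhat higher number. The expected step is a 1.5-fold higher number from compound 1 to compound 3 (0.18 log units; within the scatter), a small change in this assay. Compound 3 is therefore estimated at 8000 nM, with a likely range from 2500 nM to 25000 nM.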

Compound 3, half-maximal inhibitory concentration: 7130 nM
For compound 3 the middle estimate is 1.1-fold (0.05 log units) above the measured one; the range from low to high includes it.
By their numbers in this assay, from the lowest: compounds 1 and 3 (each within the scatter of the next); then compound 2.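

In this assay, 2-chlorophenyl in place of 3-chlorophenyl on an amide-type nitrogen gives a 1.3-fold higher number from compound 1 to compound 3 (0.13 log units; within the scatter), so these two placements of the chlorine cannot be told apart on this read-out. At this position, the result therefore does not depend measurably on which of these two chlorophenyl groups is present. No measured evidence is available to explain this result. Still open, on these data alone, is how this assay would respond if the chlorine on this ring were replaced by a different group, such as a methoxy group, an amine or a carboxylic acid.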